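The source may hold more compounds than are shown below. What is called first, only, known or untested is meant among the compounds shown, and "the series" means these compounds.

Of the compounds shown here, three have been tested in a functional assay on HT-29 cells (Homo sapiens) for cytotoxicity, read by sulforhodamine B assay, with a stated time of 48 h; on this read-out higher numbers stand for lower toxicity in this test and lower numbers for higher toxicity in this test. Compound 1 `Nc1nc(Cl)c2ncn(Cc3ccc(CCl)cc3)c2n1` gives 77600 nM in this assay. For compound 3 `ClCc1ccc(Cn2cnc3c(Cl)nc(Cl)nc32)cc1` the result in this assay is a limit of the assay, > 100000 nM. For compound 2 `ClCc1cccc(Cn2cnc3c(Cl)nc(Cl)nc32)c1` the result in this assay is likewise a limit, > 100000 nM. The difference between the cores of compound 2 and compound 3 is not broken down here. Compound 3 and compound 1 differ in one place: amino in place of chloro on an aromatic carbon. This change gave an at least 1.2-fold lower number from compound 3 to compound 1 (0.11 log units; that floor lies within the scatter). Because (the limit of > 100000 nM in this assay, at which 2 of the 3 values shown sit), that step can only be read as a floor, not as a settled size. Compound 4 `Nc1nc(Cl)c2ncn(Cc3cccc(CCl)c3)c2n1` has not yet been measured; it differs from compound 2 by the same change: amino in place of chloro on an aromatic carbon. Within the data shown here, as the only earlier example of this change rests on a limit, the expectation for compound 4 is loose. Compound 4 is expected to give about 90000 nM in this assay, most likely between 40000 nM and 200000 nM, with a real chance that only a limit is reported. That estimate means an expected step of an at least 1.1-fold lower number from compound 2 to compound 4 (0.04 log units; that floor lies within the scatter).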

Compound 4, concentration lethal to 50% of the cells: 64600 nM
The estimate for compound 4 lay 1.4-fold (0.14 log units) above the measured number, and the stated range covers the measured number.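

In this assay, amino in place of chloro on an aromatic carbon gave an at least 1.5-fold lower number from compound 2 to compound 4 (0.18 log units; that floor lies within the scatter). The change has now been seen on two cores, but the two results can be set side by side only as floors, not as sizes: the same change on two cores in this assay, an at least 1.2-fold lower number (0.11 log units; that floor lies within the scatter) from compound 3 to compound 1 and an at least 1.5-fold lower number (0.18 log units; that floor lies within the scatter) from compound 2 to compound 4; the limit leaves it open whether they differ This does not show a settled size for the change, nor that its size carries over unchanged from one core to the other, because both starting compounds give only a limit rather than a number: the limit of > 100000 nM in this assay, at which 2 of the 4 values shown sit.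

The compounds shown leave open what other groups would do at this same place, between two ring nitrogen atoms, such as a methylamino group or a methoxy group in place of the chloro group. Also open, on these data alone, is whether the change would give a step of firm size on a core whose chloro compound gives a number rather than a limit.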